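A few compounds are considered here, and "the series" means these few. Any claim that something is new, unique, unknown or untested is made for them only; others in the source may bear on it.

Measured compounds:
Compound 1, `O=C(N1CCCCC1)N1CC(c2nc(-c3cccc(Cl)c3)no2)C1`: in an assay on HEK293 cells for negative allosteric modulation of metabotropic glutamate receptor 5 (Homo sapiens), read by FLIPR (on this read-out higher numbers stand for weaker inhibition and lower numbers for stronger inhibition), compound 1 gives > 10000 nM.
Compound 2, `Cc1cccc(-c2noc(C3CN(C(=O)C4CCC(C(F)(F)F)CC4)C3)n2)c1`: in this assay compound 2 gives > 10000 nM.

The value of compound 1 is a limit of this assay, not a number. The value of compound 2 is likewise a limit. Among the measured compounds shown here, compound 1 thus stands at the limit, and the single further value shown sits there too, as the evidence states: the limit of > 10000 nM in this assay, at which 2 of the 2 values shown sit. For the measured compounds named here, no step between measured compounds that differ in one place is available, so the data give no measured size for any single change to the shared core. Compound 3, `CC1CN(C(=O)N2CC(c3nc(-c4cccc(Cl)c4)no3)C2)CC(C)O1`, is not yet measured. It differs from compound 1 by 2,6-dimethylmorpholin-4-yl in place of piperidin-1-yl on a carbonyl carbon. Because both measured values are limits, no direction can be read from them, and the expected step in this assay is a step that the limit leaves unreadable from compound 1 to compound 3, none beyond the scatter. Compound 3 is therefore estimated at 20000 nM, within a range from 5000 nM to 80000 nM, with a limit the most likely outcome.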

Compound 3, half-maximal inhibitory concentration: 990 nM
Compound 3: middle estimate off by 20-fold (1.31 log units), on the high side, outside the stated range (below it).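

Among the compounds shown here, putting 2,6-dimethylmorpholin-4-yl in place of piperidin-1-yl on the carbonyl carbon gives an at least 10-fold lower number from compound 1 to compound 3 (1.00 log units; beyond the scatter) in this assay, the first measured single change on the shared core, and it shows that the group at this place can bring a compound off the limit and onto a readable number. The value of compound 1 is a limit and not a number, so the step has a lower bound but no full size. Compound 3 is the only compound shown with a readable value, and the others remain at the limit: the limit of > 10000 nM in this assay, at which 2 of the 3 values shown sit.

The entering group brings a ring oxygen and two methyl groups at once, so the compounds shown leave open which of these goes with the step. An unsubstituted morpholin-4-yl or a 2,6-dimethylpiperidin-1-yl on the same carbonyl carbon would separate the two.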